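The source may hold more compounds than are shown below. What is called first, only, known or untested is meant among the compounds shown, and "the series" means these compounds.

In this assay, the read-out is a functional assay for agonist activity at P2Y purinoceptor 2 (Homo sapiens), read by FLIPR; on this read-out lower numbers stand for an effect already at smaller amounts and higher numbers for an effect only at larger amounts of compound. Compound 3 `O=c1c2cc(F)c(F)cc2ccn1[C@@H]1O[C@H](COP(=O)(O)OP(=O)(O)OP(=O)(O)O)[C@@H](O)[C@H]1O` gives 16 nM, the low end of the three numbers recorded so far. Compound 2 `COc1ccc2ccn([C@@H]3O[C@H](COP(=O)(O)OP(=O)(O)OP(=O)(O)O)[C@@H](O)[C@H]3O)c(=O)c2c1` gives 26 nM, a gap that stays within the usual scatter of repeated measurements, so the two cannot be ranked. Compound 1 `O=c1c2ccc(F)cc2ccn1[C@@H]1O[C@H](COP(=O)(O)OP(=O)(O)OP(=O)(O)O)[C@@H](O)[C@H]1O` gives 77 nM, and the single-point step a 4.8-fold lower number from compound 1 to compound 3 (0.68 log units; beyond the scatter) lies beyond the scatter.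

Compound 4 `CSc1cc2ccn([C@@H]3O[C@H](COP(=O)(O)OP(=O)(O)OP(=O)(O)O)[C@@H](O)[C@H]3O)c(=O)c2cc1F` differs from compound 3 in one place: methylsulfanyl in place of fluoro on an aromatic carbon. For the measured compounds named here, no measured step exchanges fluoro for methylsulfanyl. Going by the values given here, the only step recorded in this assay is the one from compound 1 to compound 3, where fluoro replaced hydrogen, and that is a different kind of change. Among the compounds with values here, compound 1 and compound 2 differ by methoxy in place of fluoro on the ring, and their values show a shift toward a lower number, though no step is recorded for that pair.

Compound 4 is therefore expected to stay close to compound 3, with a step of a 1.1-fold lower number from compound 3 to compound 4 (0.03 log units; within the scatter) not clearly beyond the scatter, and an estimated 15 nM, ranging from 5 nM to 45 nM.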

Compound 4, half-maximal effective concentration: 3 nM
Compound 4: the middle estimate sits 5.0-fold (0.70 log units) above what was measured; measured number outside the range, below it.
By their numbers in this assay, from the lowest: compound 4; then compounds 3 and 2 (each within the scatter of the next); then compound 1.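

In this assay, the step of a 5.3-fold lower number from compound 3 to compound 4 (0.73 log units; beyond the scatter) shows that this aromatic carbon, ortho to a fluoro group, accepts methylsulfanyl in place of fluoro and that the exchange moves the number clearly lower, so the fluoro at this carbon is not needed for a low number. The earlier step of a 4.8-fold lower number from compound 1 to compound 3 (0.68 log units; beyond the scatter) added a fluoro on a different aromatic carbon and so said nothing about a change at this one. Nothing measured here explains the drop.

The compounds shown leave open whether the remaining fluoro contributes to the low number of compound 4. They also leave open how this carbon would respond to a longer chain on the sulfur, such as ethylsulfanyl, or to an amine.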